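The source may hold more compounds than are shown below. What is called first, only, known or untested is meant among the compounds shown, and "the series" means these compounds.

Measured so far:
compound 1 `COc1ccc(/C=C/C(=O)c2c(O)c3ccccc3[nH]c2=O)cc1`: in an ADME assay on THP-1 cells (Homo sapiens) for cytotoxicity, read by MTT assay, with a stated time of 72 h (a higher number here means a weaker inhibitor, a lower number a stronger inhibitor), compound 1 gives > 50000 nM, a limit of the assay.
compound 2 `CC(=O)N1N=C(c2c(O)c3ccccc3[nH]c2=O)CC1c1ccccc1C`: in this assay compound 2 gives 4150 nM.
compound 3 `COc1ccc(/C=C/C(=O)c2c(O)c3ccccc3[nH]c2=O)cc1OC`: in this assay compound 3 gives > 50000 nM, again a limit.

Compound 1 thus stands only at a limit, and two of the three values sit there (the limit of > 50000 nM in this assay, at which 2 of the 3 values shown sit). Within the data shown here, the single measured step, a step that the two limits leave unreadable from compound 1 to compound 3, runs between two limits and its size cannot be read.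

Compound 4 `Cc1ccccc1/C=C/C(=O)c1c(O)c2ccccc2[nH]c1=O` differs from compound 1 by 2-methylphenyl in place of 4-methoxyphenyl on a double-bonded chain carbon bound to a double-bonded chain carbon. Among the measured compounds shown here, no measured step covers this change on the shared core. Compound 2, which carries a 2-methylphenyl on a different core, gives 4150 nM in this assay, a number rather than a limit, which keeps a weak signal possible.

Compound 4 is estimated at 40000 nM, with a range from 8000 nM to 100000 nM. The expected step of an at least 1.2-fold lower number from compound 1 to compound 4 (0.09 log units; that floor lies within the scatter) is no change beyond the scatter, most likely another limit.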

Compound 4, half-maximal inhibitory concentration: > 50000 nM
Compound 4 was reported as a limit; the forecaster's own chance of this, stated with the estimate: 60%; middle value at least 1.2-fold (0.09 log units) away from the limit.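

In this assay compound 4 gives > 50000 nM, a limit. Among these compounds, compound 1 also stands at a limit, so no step between compound 1 and compound 4 can be read. The compounds shown leave open whether 2-methylphenyl and 4-methoxyphenyl differ at all on the shared core: the limit of > 50000 nM in this assay, at which 3 of the 4 values shown sit.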